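Cyanoamino for Sulfanyl: Expected Effect on Gastric Dose

The compounds below may be only part of what the source reports. "The series", "measured", "known", "first", "only" and "open" are said of these compounds alone.

Compound 1, `O=c1ccc(-c2ccccc2)nn1CCCCNC(=S)Nc1ccccc1`. In a functional assay on the whole organism (stomach) with Rattus norvegicus as the target (on this read-out lower numbers stand for an effect already at smaller amounts and higher numbers for an effect only at larger amounts of compound), compound 1 gives > 100 mg/kg, which is a limit of the assay and not a number.
Compound 2, `C/N=C(\S)NCCCCn1nc(-c2ccccc2)ccc1=O`. In this assay compound 2 gives 28.9 mg/kg.

Within the data shown here, compound 2 holds the only number that has been measured; the other value recorded is a limit, as the limit of > 100 mg/kg in this assay, at which 1 of the 2 values shown sits, shows. Among the measured compounds shown here, the single measured step, an at least 3.4-fold lower number from compound 1 to compound 2 (0.53 log units; beyond the scatter), concerns a change on an amine nitrogen and so tells little about a change elsewhere. Compound 3, `C/N=C(\NC#N)NCCCCn1nc(-c2ccccc2)ccc1=O`, differs from compound 2 by cyanoamino in place of sulfanyl on a carbon with a double bond to nitrogen. For the measured compounds named here, no measured step touches that carbon, so the only guide is the value of compound 2 itself. The step from compound 2 to compound 3 is therefore expected to stay within the scatter, a 1.0-fold higher number from compound 2 to compound 3 (0.02 log units; within the scatter). Compound 3 is estimated to give 30 mg/kg in this assay, between 10 mg/kg and 90 mg/kg.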

Compound 3, dose for half-maximal effect: 32.4 mg/kg
Beside the measured number, compound 3's estimate is 1.1-fold (0.03 log units) below it; low and high end bracket the measured number.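

On the carbon with a double bond to nitrogen, the exchange of sulfanyl for cyanoamino gives a 1.1-fold higher number from compound 2 to compound 3 (0.05 log units; within the scatter), so in this assay this position tolerates the swap without a change that stands out from the scatter. The group on the amine nitrogen still matters with cyanoamino in place, as the second comparison reads an at least 3.0-fold lower number from compound 1 to compound 3 (0.48 log units; beyond the scatter), and the lower number seen with the smaller group therefore holds for both groups on that carbon. Compound 1 remains a limit of the assay and not a number, so the size of that step stays open on one side: the limit of > 100 mg/kg in this assay, at which 1 of the 3 values shown sits.

The compounds shown leave open whether an amine or a carboxylic acid on that same carbon would fit as well as these two groups. They also leave open how a longer chain in place of the present one would read in this assay.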